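The source may hold more compounds than are shown below. What is called first, only, known or untested is meant among the compounds shown, and "the series" means these compounds.

Compound 3 `Cc1nc(-c2ccc(C(F)(F)F)cc2)sc1CNc1ccc(CC(C)C(=O)O)cc1` gives 355 nM in a functional assay on CHO cells for agonist activity at Free fatty acid receptor 1 (Homo sapiens); on this read-out higher numbers stand for an effect only at larger amounts of compound and lower numbers for an effect already at smaller amounts. Among the three measured members it carries the highest number; its nearest neighbour is compound 2 `Cc1nc(-c2ccc(C(F)(F)F)cc2)sc1CNc1ccc(OCC(=O)O)cc1` with 288 nM, and the furthest is compound 1 `O=C(O)/C=C/c1ccc(NCc2cccc(Oc3ccccc3)c2)cc1` with 145 nM. For the measured compounds named here, the only single-point step recorded in the set is a 1.2-fold higher number from compound 2 to compound 3 (0.09 log units; within the scatter), so the two acid-bearing chains on the shared core of compound 2 behave alike.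

Compound 4 `Cc1nc(-c2ccc(C(F)(F)F)cc2)sc1CNc1ccc([C@H]2C[C@@H]2C(=O)N(C)C)cc1` differs from compound 3 at one place: 2-(dimethylcarbamoyl)cyclopropyl in place of 2-carboxypropyl on an aromatic carbon. Going by the values given here, no measured step covers this kind of change. The step from compound 2 to compound 3 exchanges one chain for another while keeping the carboxylic acid, and it tells nothing about what happens once the acid is gone and a dimethylcarbamoyl on a cyclopropyl stands in its place. The gap between compound 1 and compound 3 also rests on two different cores and on two acids, not on the loss of one.

Among the compounds with values here, with no bearing step in hand, compound 4 is expected to give a number larger than that of compound 3, the estimated step being a 4.2-fold higher number from compound 3 to compound 4 (0.63 log units; beyond the scatter), with wide uncertainty. For compound 4 the estimate in this assay is 1500 nM, expected to lie between 300 nM and 8000 nM.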

Compound 4, half-maximal effective concentration: 66.1 nM
The estimate for compound 4 lay 23-fold (1.36 log units) above the measured number, and the stated range ends above it.
By their numbers in this assay, from the lowest: compound 4; then compounds 1, 2 and 3 (each within the scatter of the next, the first and the last beyond it).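

In this assay, this position, an aromatic carbon para to a large group, keeps its effect without a carboxylic acid: 2-(dimethylcarbamoyl)cyclopropyl in place of 2-carboxypropyl gives a 5.4-fold lower number from compound 3 to compound 4 (0.73 log units; beyond the scatter), and the same group in place of carboxymethoxy gives a 4.4-fold lower number from compound 2 to compound 4 (0.64 log units; beyond the scatter). For the compounds shown here, every earlier compound carried a carboxylic acid, and the only earlier step on the shared core exchanged one acid-bearing chain for another, whereas this change brings in a chain with a three-membered carbon ring, two defined stereocentres and 0 hydrogen-bond donors, and both steps lie beyond the scatter. No measurement at hand accounts for these steps.

The change alters several features at once, so the compounds shown do not separate the contribution of the loss of the carboxylic acid from those of the cyclopropyl ring and the dimethylcarbamoyl group. From the compounds shown here alone, a carboxylic acid carried directly on the cyclopropyl ring, an open-chain dimethylcarbamoyl group and the mirror-image cyclopropyl form would each bear on this question, and the step's dependence on the two methyl groups of the amide also remains open.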